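This account rests on a few compounds, and the source may have more. Where it says the series, first, only, none or still open, it means among the compounds named here.

Measured so far in an assay on cell membranes for displacement of a labelled ligand from metabotropic glutamate receptor 5 (Rattus norvegicus), with a stated time of 60 min, tested at 1 uM; on this read-out lower numbers stand for less inhibition and higher numbers for more inhibition at the one concentration tested (going by the name of the read-out):
compound 1 `O=S(=O)(c1ccc(F)cc1)c1cnc2cc(Cl)c(F)cc2c1-c1ccc(Cl)cc1` gives 48%;
compound 2 `O=S(=O)(c1ccc(F)cc1)c1cnc2ccc(F)cc2c1-c1ccc(Cl)cc1` gives 76.3%.

Compound 2 stands highest of the two numbers, with compound 1 the nearest and lower. For the measured compounds named here, the only measured step, a number 28.3 percentage points higher from compound 1 to compound 2 (beyond the scatter), concerns hydrogen in place of chloro on an aromatic carbon and does not bear on the change now at hand. Compound 3 `N#Cc1ccc2ncc(S(=O)(=O)c3ccc(F)cc3)c(-c3ccc(Cl)cc3)c2c1` differs from compound 2 by cyano in place of fluoro on an aromatic carbon. Going by the values given here, no measured pair shows an exchange of this kind, so no step beyond the scatter is expected in either direction. The estimate for compound 3 is 66%, between 35% and 92%, an expected step of a number 10.3 percentage points lower from compound 2 to compound 3 (beyond the scatter).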

Compound 3, a percentage reported as inhibition, at one concentration (the size of the read-out at that concentration, not a potency): 39.7%
Beside the measured number, compound 3's estimate is 26.3 percentage points above it; measured number inside the range.
By their numbers in this assay, from the lowest: compounds 3 and 1 (each within the scatter of the next); then compound 2.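

At this aromatic carbon, para to a fused ring, the read-out in this assay depends on the group present: cyano in place of fluoro gives a number 36.6 percentage points lower from compound 2 to compound 3 (beyond the scatter). This is the first exchange shown at this carbon, and it leaves fluoro as the better of the two groups here. Nothing on hand accounts for the size of this step.

Only fluoro and cyano are shown at this carbon, so the readings for methoxy, an amine or a carboxylic acid there remain open. Going by these compounds, whether the step holds with other groups elsewhere on the shared core also remains open.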